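Ester and amide variants at the acrylamide carbonyl

The source may hold more compounds than are shown below. What is called first, only, known or untested is meant among the compounds shown, and "the series" means these compounds.

Measured so far:
compound 1 `CCOc1cc(NC(=O)C2(NC(=O)c3ccc4c(C5CCCC5)c(-c5ncc(Cl)cn5)n(C)c4c3)CCC2)ccc1/C=C/C(=O)N[C@@H](CCC(=O)O)C(N)=O` — 4.23 h in an ADME assay for pharmacokinetics, in simulated intestinal fluid; a higher number here means that the compound lasts longer, a lower number that the compound disappears faster
compound 2 `CCOc1cc(NC(=O)C2(NC(=O)c3ccc4c(C5CCCC5)c(-c5ncc(Cl)cn5)n(C)c4c3)CCC2)ccc1/C=C/C(=O)OCC(Cl)(Cl)Cl` — in this assay compound 2 reaches only a limit, > 5 h

Among the compounds with values here, compound 1 carries the only definite number in the set; the other result is a limit. Within the data shown here, the one measured step, an at least 1.1-fold higher number from compound 1 to compound 2 (0.07 log units; that floor lies within the scatter), sits at a floor within the scatter and ends at the limit (the limit of > 5 h in this assay, at which 1 of the 2 values shown sits).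

Compound 3 `CCOc1cc(NC(=O)C2(NC(=O)c3ccc4c(C5CCCC5)c(-c5ncc(Cl)cn5)n(C)c4c3)CCC2)ccc1/C=C/C(=O)OCC(=O)N1CCOCC1` differs from compound 1 by ((morpholin-4-yl)carbonyl)methoxy in place of (1-carbamoyl-3-carboxypropyl)amino on a carbonyl carbon. The measured step that bears on this change is an at least 1.1-fold higher number from compound 1 to compound 2 (0.07 log units; that floor lies within the scatter), which also replaces the (1-carbamoyl-3-carboxypropyl)amino group on the same carbonyl carbon with an alkoxy group. From that step no more than a small rise beyond the scatter is expected, with a fair chance that the assay again reports only a limit.

Compound 3 is expected to give 4.8 h in this assay. For compound 3 the estimated range runs from 2.4 h to 9 h. The expected step is a 1.1-fold higher number from compound 1 to compound 3 (0.05 log units; within the scatter).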

Compound 3, half-life: 3.17 h
Compound 3: middle estimate off by 1.5-fold (0.18 log units), on the high side; measured number inside the range.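

Within the data shown here, compound 3 gives the only definite number for an ester on this carbonyl carbon in this assay, whereas the other ester, compound 2, reaches only a limit. The amide-to-ester change shows a 1.3-fold lower number from compound 1 to compound 3 (0.13 log units; within the scatter), so ((morpholin-4-yl)carbonyl)methoxy and (1-carbamoyl-3-carboxypropyl)amino cannot be told apart here, even though the entering group has no hydrogen-bond donors or defined stereocentre. Between the two esters there is an at least 1.5-fold lower number from compound 2 to compound 3 (0.19 log units; that floor lies within the scatter), which establishes no difference, and the value of compound 2 is a limit: the limit of > 5 h in this assay, at which 1 of the 3 values shown sits.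

Going by these compounds, the true gap between (morpholin-4-yl)carbonyl and trichloromethyl on the saturated chain carbon stays open. Also open, on these data alone, is how a plain ethoxy group, or a free carboxylic acid, on this carbonyl carbon would read in this assay.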